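A few compounds are considered here, and "the series" means these few. Any claim that something is new, unique, unknown or untested is made for them only; others in the source may bear on it.

Measured so far in a functional assay on the whole organism with Rattus norvegicus as the target; on this read-out lower numbers stand for an effect already at smaller amounts and higher numbers for an effect only at larger amounts of compound:

compound 1 (`CCOC(=O)C(=O)Nc1cccc(N(C)C)c1C#N`) gives 4.2 mg/kg
compound 2 (`CCOC(=O)C(=O)Nc1ccc(N)cc1C#N`) gives 8.8 mg/kg
compound 3 (`CCOC(=O)C(=O)Nc1cc(N(C)C)ccc1C#N`) gives > 100 mg/kg which is a limit of the assay and not a number

Compound 1 has the lower of the two actual numbers (4.2 mg/kg), and compound 2 comes next (8.8 mg/kg), a gap just beyond the usual scatter.

The next compound to be tested is compound 4 (`CCNc1cccc(NC(=O)C(=O)OCC)c1C#N`), which has the same atoms as compound 1, joined differently. It carries ethylamino in place of dimethylamino on an aromatic carbon, ortho to a cyano group and meta to a group of 8 heavy atoms (ethylamino in place of dimethylamino on an aromatic carbon).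

Among the measured compounds shown here, no measured pair shows this exact swap, so any expectation is loose. The new group keeps a hydrogen on its nitrogen. Compound 2 also has hydrogens on its amino nitrogen, at a different place on the shared core, and it still gives a real number (8.8 mg/kg). A collapse in this assay therefore seems unlikely, and a modest move toward a higher number seems more likely. The estimated step is a 1.7-fold higher number from compound 1 to compound 4 (0.22 log units; within the scatter) and remains an expectation. For compound 4 the estimate is 7 mg/kg with an expected range from 2 mg/kg to 30 mg/kg in this read-out.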

Compound 4, dose for half-maximal effect: 0.03 mg/kg
Beside the measured number, compound 4's estimate is 230-fold (2.37 log units) above it, and the stated range ends above it.
By their numbers in this assay, from the lowest: compound 4; then compound 1; then compound 2. At a limit, above all of these: compound 3.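

In this assay the swap of dimethylamino for ethylamino on this aromatic carbon, ortho to a cyano group and meta to a group of 8 heavy atoms, gives a 140-fold lower number from compound 1 to compound 4 (2.15 log units; beyond the scatter) and so shows that this position is highly sensitive to the exact form of its substituent. The two groups contain the same atoms and each has 3 heavy atoms, so a large step can arise here without any change in the atoms present; the counted difference is 1 hydrogen-bond donor on ethylamino and 0 on dimethylamino. Nothing measured for these compounds explains why the step is so large.

The compounds shown leave open whether the hydrogen on the nitrogen or the ethyl chain matters more, and methylamino or propylamino at this same position would help separate those two readings. Also open, from the compounds shown here alone, is whether the same swap would give a step of similar size at other places on the shared core.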